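Acetylating a hydroxy group on a weak cytotoxic compound

The source may hold more compounds than are shown below. What is called first, only, known or untested is meant among the compounds shown, and "the series" means these compounds.

Values in a functional assay on K562 cells (Homo sapiens) for cytotoxicity, read by XTT assay; a higher number here means a weaker inhibitor, a lower number a stronger inhibitor:
- compound 1 `C/C(=C\[C@@H](O)C/C(C)=C/CCc1ccoc1)CC[C@@H](O)[C@]1(C)CCC(=O)O1` gives 7800 nM
- compound 2 `C/C(=C\[C@@H](O)C/C(C)=C/CCCC(=O)CO)CC[C@@H](O)[C@]1(C)CCC(=O)O1` gives > 20000 nM, which is a limit and not a number

Going by the values given here, compound 1 holds the only true number in this small set, since the other value is a limit. Compound 3 `CC(=O)O[C@H](CC/C(C)=C/[C@@H](O)C/C(C)=C/CCc1ccoc1)[C@]1(C)CCC(=O)O1` differs from it in one place: acetyl in place of hydrogen on an oxygen on a saturated carbon. This turns hydroxy to acetoxy.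

Among the compounds with values here, the single measured step is an at least 2.5-fold higher number from compound 1 to compound 2 (0.40 log units; beyond the scatter). It replaces furan-3-yl and leaves this oxygen untouched, so it bears on the new change only indirectly. Its size is also only a lower bound because of the limit of > 20000 nM in this assay, at which 1 of the 2 values shown sits. Within the data shown here, it shows that this assay can respond to a change in this molecule, but no measured step gives the size or direction of an acetyl change.

The expectation therefore stays close to compound 1 at 7800 nM, with no step beyond the scatter in this assay. The expected change is a 1.3-fold lower number from compound 1 to compound 3 (0.11 log units; within the scatter). For compound 3 the estimated value is 6000 nM, with an expected range of 2000 nM to 20000 nM.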

Compound 3, half-maximal inhibitory concentration: 5400 nM
Compound 3: middle estimate off by 1.1-fold (0.05 log units), on the high side, within the range that was stated.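

In this assay, going by these compounds alone, acetyl in place of hydrogen on this oxygen gives a 1.4-fold lower number from compound 1 to compound 3 (0.16 log units; within the scatter), which is the first measured step at this site. Within this one pair, turning hydroxy to acetoxy produces no change that can be told apart from the ordinary variation between repeated measurements, so the free hydroxy hydrogen shows no measurable importance for this cytotoxicity reading, and the acetoxy group does not cost or gain anything that can be detected. Nothing shown explains why the two compounds read alike, and this single pair cannot separate a truly neutral change from effects that happen to cancel out.

As far as these compounds go, one acyl group on one oxygen says little about this site as a whole, so it remains open whether a longer chain such as hexanoyl, a benzoyl group, a methyl ether or an amine in place of the hydroxy group would also leave the reading within the scatter. From the compounds shown here alone, the same question stands for the other hydroxy group on the chain, where the effect of acetyl remains unknown, and for whether any change at either oxygen could give a clear gain on compound 1.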